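Compound 3 in the agonist assay: an expectation from thin data

This account rests on a few compounds, and the source may have more. Where it says the series, first, only, none or still open, it means among the compounds named here.

Compound 1 `CC(Oc1ccccc1)C(=O)Nc1ccc(OCC(=O)O)c(F)c1` and compound 2 `CC(Oc1ccccc1F)C(=O)Nc1ccc(OCC(=O)O)c(F)c1` share one core. Among the compounds with values here, in a functional assay on CHO cells for agonist activity at Free fatty acid receptor 1 (Homo sapiens), read by FLIPR, tested at 100 nM (a lower number here means a weaker effect, a higher number a stronger effect of the compound at the concentration tested), compound 1 gives 35.7%, and compound 2 gives 35.1%; the only measured step, a number 0.6 percentage points lower from compound 1 to compound 2 (within the scatter), is a fluoro in place of hydrogen on an aromatic carbon and stays within the scatter. Compound 2 therefore stands level with compound 1. Compound 3 `CCOc1ccc(OC(C)C(=O)Nc2ccc(OCC(=O)O)c(F)c2)cc1` differs from compound 2 by 4-ethoxyphenyl in place of 2-fluorophenyl on an oxygen on a saturated carbon. Within the data shown here, no measured step covers a change of this size, so the expected step of a number 0.1 percentage points lower from compound 2 to compound 3 (within the scatter) is small. Compound 3 is estimated at 35%, between 15% and 55%.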

Compound 3, a percentage reported as activity, at one concentration (the size of the read-out at that concentration, not a potency): 3.56%
Beside the measured number, compound 3's estimate is 31.4 percentage points above it, and the stated range ends above it.
By their numbers in this assay, from the lowest: compound 3; then compounds 2 and 1 (each within the scatter of the next).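

In this assay the group on an oxygen on a saturated carbon proves able to change the read-out: 4-ethoxyphenyl in place of 2-fluorophenyl gives a number 31.5 percentage points lower from compound 2 to compound 3 (beyond the scatter) and the addition of the ethoxy group alone gives a number 32.1 percentage points lower from compound 1 to compound 3 (beyond the scatter) where the fluoro step had stayed within the scatter. The ring at this position thus accepts the fluoro of compound 2 without a measurable change but not the ethoxy of compound 3. Nothing available explains this loss. Going by these compounds, how a methoxy or a chloro group in place of the ethoxy would read stays open.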